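A few compounds are considered here, and "the series" means these few. Any claim that something is new, unique, unknown or untested is made for them only; others in the source may bear on it.

Compound 1 `CCCCCCCCc1ccc(C(=O)C[C@@H]2CCCN2)cc1` gives 2500 nM 
Compound 2 `CCCCCCCCc1ccc(CC[C@@H]2CCCN2)cc1` gives 2800 nM 

In a functional assay on FL5.12 cells (Mus musculus) for cytotoxicity, read by flow cytometry and propidium iodide staining, with a stated time of 48 h (on this read-out lower numbers stand for stronger inhibition and higher numbers for weaker inhibition), compound 1 and compound 2 lie within the scatter of each other, so compound 1 holds no clear rank. Compound 3 `CCCCCCCCc1ccc(C(=O)CC[C@H]2C[C@H](CO)CN2)cc1` keeps the shared octyl-bearing part of compound 1, and the change is a group of 8 heavy atoms (6 carbon, 1 nitrogen, 1 oxygen; one five-membered non-aromatic ring with 1 hetero atom) in place of a group of 5 heavy atoms (4 carbon, 1 nitrogen; one five-membered non-aromatic ring with 1 hetero atom), on a saturated chain carbon bound to a carbonyl carbon on a saturated chain carbon bound to a carbonyl carbon. Going by the values given here, no measured pair isolates this change, so the data offer no step to carry over. In this assay no step beyond the scatter is expected, and the estimated step is a 1.2-fold higher number from compound 1 to compound 3 (0.08 log units; within the scatter) in size. Compound 3 is expected at 3000 nM (estimated range 1400 nM to 6500 nM).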

Compound 3, half-maximal inhibitory concentration: 4000 nM
For compound 3 the middle estimate is 1.3-fold (0.12 log units) below the measured one; measured number inside the range.
By their numbers in this assay, from the lowest: compounds 1, 2 and 3 (each within the scatter of the next).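

In this assay, going by these compounds alone, the group of 8 heavy atoms, with 2 hydrogen-bond donors and 2 acceptors, replaces pyrrolidin-2-yl on a saturated chain carbon bound to a carbonyl carbon, giving a 1.6-fold higher number from compound 1 to compound 3 (0.20 log units; within the scatter) as the only step read at this place. This larger group therefore leaves the number within the scatter of compound 1. No measurement on hand offers an explanation for this result. Still open, on these data alone, is whether a carboxylic acid or a primary amine at this place would give a step beyond the scatter. Also open, as far as these compounds go, is whether a chain longer than octyl would do so.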